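Amino Replacement at the Pyrazole Carbon: Azepanyl for Cyclopropyl

This account rests on a few compounds, and the source may have more. Where it says the series, first, only, none or still open, it means among the compounds named here.

Three compounds share one core and differ only in the group borne on an aromatic carbon of the fused bicyclic system. Compound 1 `O=C(O)c1cccc(Cc2c(-c3cccc(Cl)c3)nn3cc(Cl)ccc23)n1` gives 480 nM in a functional assay on cells for antagonist activity at prostaglandin E2 receptor EP1 subtype (Rattus norvegicus), read by fluorescence and calcium flux, with a stated time of 60 s; a lower number here means a stronger inhibitor, a higher number a weaker inhibitor. Compound 2 `O=C(O)c1cccc(Cc2c(-c3cccs3)nn3cc(Cl)ccc23)n1` gives 1100 nM in this assay, and compound 3 `O=C(O)c1cccc(Cc2c(C3CC3)nn3cc(Cl)ccc23)n1` gives 1500 nM there. Compound 3 thus has the highest number of the three: the change a 3.1-fold higher number from compound 1 to compound 3 (0.49 log units; beyond the scatter) lies beyond the scatter, the change a 1.4-fold higher number from compound 2 to compound 3 (0.13 log units; within the scatter) does not, and a 2.3-fold higher number from compound 1 to compound 2 (0.36 log units; beyond the scatter) sets the remaining pair.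

Compound 4 `O=C(O)c1cccc(Cc2c(N3CCCCCC3)nn3cc(Cl)ccc23)n1` is not yet measured. It differs from compound 3 in that (azepan-1-yl in place of cyclopropyl on an aromatic carbon). The measured steps all concern exchanges at this same carbon, but none of them introduces a ring-bound nitrogen, so they bear on the place only, not on the group. The two non-aromatic-versus-aromatic steps were modest, and the one between the two smaller groups lay within the scatter. Compound 4 is therefore expected to give 1300 nM in this assay, within 400 nM to 4500 nM, so that the estimated step of a 1.2-fold lower number from compound 3 to compound 4 (0.06 log units; within the scatter) stays within the scatter.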

Compound 4, half-maximal inhibitory concentration: 1400 nM
The estimate for compound 4 lay 1.1-fold (0.03 log units) below the measured number; measured number inside the range.
By their numbers in this assay, from the lowest: compound 1; then compounds 2, 4 and 3 (each within the scatter of the next).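

With azepan-1-yl, a seven-membered non-aromatic ring attached through its nitrogen, now on this aromatic carbon, a 1.1-fold lower number from compound 3 to compound 4 (0.03 log units; within the scatter) in this assay shows that replacing the three-membered carbon ring with this group leaves the number unchanged within the scatter. Compared with thiophen-2-yl, a 1.3-fold higher number from compound 2 to compound 4 (0.10 log units; within the scatter) is likewise within the scatter, whereas a 2.9-fold higher number from compound 1 to compound 4 (0.46 log units; beyond the scatter) lies beyond it, so among these four compounds only the one with 3-chlorophenyl stands apart from the others. No evidence here bears on the reason for this result.

Going by these compounds, it remains open whether an open-chain dimethylamino group or the smaller rings of pyrrolidin-1-yl and morpholin-4-yl would match azepan-1-yl at this carbon. Also open, on these data alone, is whether unsubstituted phenyl would match 3-chlorophenyl or fall with the other three groups.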